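A few compounds are considered here, and "the series" means these few. Any claim that something is new, unique, unknown or untested is made for them only; others in the source may bear on it.

In an ADME assay on HEK293 cells (Homo sapiens) for inhibition, read by MTT assay, with a stated time of 3 days (a lower number here means a stronger inhibitor, a higher number a weaker inhibitor), compound 1 `COc1ccc(COc2cc(/C=C\c3cc(OC)c(OC)c(OC)c3)ccc2OC)cc1` gives 64000 nM and compound 2 `COc1ccc(/C=C/CCCOc2cc(/C=C\c3cc(OC)c(OC)c(OC)c3)ccc2OC)cc1` gives 88000 nM, two values within the scatter of each other. Compound 3 `COc1ccc(/C=C\c2cc(OC)c(OC)c(OC)c2)cc1OCCC/C=C/c1ccc(F)cc1` differs from compound 2 by fluoro in place of methoxy on an aromatic carbon, para to a large group: fluoro in place of methoxy on an aromatic carbon. Among the compounds with values here, the only measured step, a 1.4-fold higher number from compound 1 to compound 2 (0.14 log units; within the scatter), concerns the chain and not this substituent, so it bears on the change only indirectly. No shift beyond the scatter is expected in this assay. The expected step is a 1.3-fold lower number from compound 2 to compound 3 (0.10 log units; within the scatter). For compound 3 the estimated value is 70000 nM, with an expected range of 30000 nM to 160000 nM.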

Compound 3, half-maximal inhibitory concentration: 115000 nM
Compound 3: the middle estimate sits 1.6-fold (0.22 log units) below what was measured; the range from low to high includes it.
By their numbers in this assay, from the lowest: compounds 1, 2 and 3 (each within the scatter of the next).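

In this assay, fluoro in place of methoxy on an aromatic carbon, para to a large group, gives a 1.3-fold higher number from compound 2 to compound 3 (0.12 log units; within the scatter), so this position tolerates the exchange without a shift beyond the scatter. The larger replacement on the saturated chain carbon, 4-(4-fluorophenyl)but-3-en-1-yl for 4-methoxyphenyl, gives a 1.8-fold higher number from compound 1 to compound 3 (0.25 log units; within the scatter), so it also stays within the scatter. No measurement shown accounts for these results.

Open, going by these compounds, is whether an amine or a carboxylic acid at this aromatic carbon would move the number beyond the scatter. On these data alone, a longer chain also remains open.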